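The source may report more compounds than this note shows. Statements on the series, on what has been measured and on what is new or still open speak of the compounds shown alone.

Measured compounds:

compound 1, `Brc1ccccc1COc1nc2ccccc2s1`, 51.9%
compound 2, `c1ccc(COc2nc3ccccc3s2)cc1`, 51.9%
compound 3, `COc1ccc(COc2nc3ccccc3s2)cc1`, reported as "not active" (no number reported) without a number

In a functional assay on the whole organism with Mus musculus as the target, in the writhing test, at a dose of 100 mg/kg by the intraperitoneal route (a lower number here means less inhibition, a higher number more inhibition at the dose given (going by the name of the read-out)), compound 2 gives 51.9%. Compound 2 stands level with compound 1 at the digits shown; the single step of one change in the set, no change at the digits printed from compound 1 to compound 2 (within the scatter), lies within the scatter. Within the data shown here, compound 3, with a methoxy group on the phenyl ring, is reported as not active in this assay and carries no number, so it gives no measured step to compound 2.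

Compound 4, `FC(F)(F)c1ccccc1COc1nc2ccccc2s1`, is not yet measured in this assay. It differs from compound 2 by trifluoromethyl in place of hydrogen on an aromatic carbon. Among the measured compounds shown here, the step from compound 1 to compound 2 is the only measured step that bears on a change at this position of the ring, and it shows no change beyond the scatter when a bromo group on the aromatic carbon is exchanged for hydrogen. Compound 3 shows that a substituent elsewhere on the ring can remove activity altogether, so the scatter of the expectation is wide. On these numbers the step of a number 1.9 percentage points lower from compound 2 to compound 4 (within the scatter) is expected to be small, in either direction, within the scatter. Compound 4 is therefore estimated at 50% in this assay, with a range from 30% to 65%.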

Compound 4, a percentage reported as inhibition, in the whole organism at one dose (the size of the read-out at that dose, not a potency): "not active" (no number reported)
For compound 4 the study gives words and no number; the estimate stays without a comparison.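

Among these compounds, compound 2 gives 51.9% in this assay and compound 4 is reported there as not active without a number, so no step between them can be read. The compounds shown leave open whether compound 3 and compound 4 retain any measurable inhibition at this dose. Nothing shown bears on a cause for this result.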